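A few compounds are considered here, and "the series" means these few. Any claim that something is new, unique, unknown or untested is made for them only; others in the source may bear on it.

- Compound 1 `Nc1nc2cc(Cl)c(Cl)cc2n1Cc1ccc(Cl)c(Cl)c1`: 30000 nM
- Compound 2 `Clc1ccc(Cn2c(Cl)nc3cc(Cl)c(Cl)cc32)cc1Cl`: > 100000 nM, a limit
- Compound 3 `Clc1ccc(Cn2c(Br)nc3cc(Cl)c(Cl)cc32)cc1`: > 100000 nM, a limit

These values come from a functional assay on CEM-SS cells (Homo sapiens) for cytotoxicity; on this read-out lower numbers stand for stronger inhibition and higher numbers for weaker inhibition. Compound 3 stands at the limit of > 100000 nM in this assay, at which 2 of the 3 values shown sit, so it has a limit of this assay and not a true number. Compound 4 `Clc1ccc(Cn2c(Br)nc3cc(Cl)c(Cl)cc32)cc1Cl` differs from compound 3 by one change: chloro in place of hydrogen on an aromatic carbon. Going by the values given here, no measured step makes this exact change. Among the compounds with values here, the one measured step, an at least 3.3-fold higher number from compound 1 to compound 2 (0.52 log units; beyond the scatter), is a different change: chloro in place of amino on an aromatic carbon. Compound 2 carries the same added chloro group, and its > 100000 nM is also a limit. The expected change is a number no higher from compound 3 to compound 4 (the limit leaves the size open), with nothing beyond the scatter foreseen. Compound 4 is estimated at 100000 nM, with an expected range of 40000 nM to 200000 nM.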

Compound 4, half-maximal inhibitory concentration: > 100000 nM
Compound 4: no number, only a limit; the forecaster's own chance of this, stated with the estimate: 85%; the middle value sits exactly at the limit.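

Compound 4 also gives only a limit in this assay, not a number, so the added chloro ortho to a chloro group produces no readable change, and the steps to compound 3 and compound 2 cannot be read. Bromo in place of amino gives an at least 3.3-fold higher number from compound 1 to compound 4 (0.52 log units; beyond the scatter), so among these compounds only the amino compound has a true number: the limit of > 100000 nM in this assay, at which 3 of the 4 values shown sit.

From the compounds shown here alone, whether a methyl group or a carboxylic acid in place of the amino group would give a true number stays open. Going by these compounds, the size of the chloro step on its own also stays open.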